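This account rests on a few compounds, and the source may have more. Where it says the series, first, only, none or still open, it means among the compounds named here.

Measured in a functional assay on HCT-116 cells (Homo sapiens) for antiproliferative activity, read by MTT assay, with a stated time of 72 h; a higher number here means a weaker inhibitor, a lower number a stronger inhibitor:

Compound 1 `O=C(CCc1cccc2c1B(O)OC2)Nc1ccc(F)cc1`: 650 nM
Compound 2 `CC(C)(C)c1ccc(NC(=O)CCc2cccc3c2B(O)OC3)cc1`: 19000 nM
Compound 3 `COc1ccc(NC(=O)CCc2cccc3c2B(O)OC3)cc1`: 1700 nM

Compound 3, at 1700 nM, holds the second highest of the three numbers in this assay. It lies above compound 1 and below compound 2, and its gaps to both are beyond the scatter. The next compound, compound 4 `O=C(CCc1cccc2c1B(O)OC2)Nc1ccc(-c2ccccc2)cc1`, keeps the shared core and the amide chain but carries phenyl in place of methoxy on an aromatic carbon, para to a large group (phenyl in place of methoxy on an aromatic carbon).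

Going by the values given here, no measured compound carries phenyl, so the guidance is indirect. All three measured steps change the group at this same place. The step of a 2.6-fold higher number from compound 1 to compound 3 (0.42 log units; beyond the scatter) is modest, whereas a 29-fold higher number from compound 1 to compound 2 (1.47 log units; beyond the scatter) and an 11-fold lower number from compound 2 to compound 3 (1.05 log units; beyond the scatter) are both large. Compound 2 is the closest guide, as its tert-butyl also contains only carbon, and it shows that a group of this kind can cost much in this assay. On these data alone, how closely phenyl follows tert-butyl remains unknown, so a moderate rise is expected rather than the full size of that step. The expected change is a 2.9-fold higher number from compound 3 to compound 4 (0.47 log units; beyond the scatter). For compound 4 the estimated value is 5000 nM, with an expected range from 1300 nM to 19000 nM.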

Compound 4, half-maximal inhibitory concentration: 13000 nM
Compound 4: middle estimate off by 2.6-fold (0.41 log units), on the low side; measured number inside the range.
By their numbers in this assay, from the lowest: compound 1; then compound 3; then compounds 4 and 2 (each within the scatter of the next).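

In this assay, phenyl on this aromatic carbon, para to a large group, gives a 7.6-fold higher number from compound 3 to compound 4 (0.88 log units; beyond the scatter) and a 20-fold higher number from compound 1 to compound 4 (1.30 log units; beyond the scatter) in the series, which makes it a second group of carbon only that sits far from fluoro. The step of a 1.5-fold lower number from compound 2 to compound 4 (0.16 log units; within the scatter) lies within the scatter, and the ring of phenyl and the open tert-butyl cannot be told apart at this place: across these four compounds the numbers run from fluoro to methoxy and then to phenyl and tert-butyl together, with none going against that order. Nothing measured here gives a reason for these steps.

On these data alone, whether an amine or a carboxylic acid on this aromatic carbon would bring the number back toward that of compound 1 at 650 nM stays open, as does whether chloro would behave like fluoro. Every step shown falls at this one place, and what a longer amide chain or a change in the shared core would do in this assay also remains unknown.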